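Hydroxymethyl in Place of Chloromethyl on a Coumarin-Type Core

The source may report more compounds than this note shows. Statements on the series, on what has been measured and on what is new or still open speak of the compounds shown alone.

Measured compounds:
Compound 1 `O=c1cc(O)c2ccc(OCc3cccc(Br)c3)cc2o1` gives 490 nM in an assay on isolated protein (strain Sprague-Dawley) for inhibition of Amine oxidase [flavin-containing] B (Rattus norvegicus), read by spectrophotometry, with a stated time of 5 min; on this read-out higher numbers stand for weaker inhibition and lower numbers for stronger inhibition.
Compound 2 `O=c1cc(CCl)c2ccc(OCc3cccc(Br)c3)cc2o1` gives 209 nM in this assay.

Among the measured compounds shown here, compound 2 holds the lower of the two numbers so far; the step from compound 1 to it was a 2.3-fold lower number from compound 1 to compound 2 (0.37 log units; beyond the scatter). Compound 3 `O=c1cc(CO)c2ccc(OCc3cccc(Br)c3)cc2o1` differs from compound 2 by hydroxy in place of chloro on a saturated chain carbon bound to an aromatic carbon. For the measured compounds named here, no measured step covers exactly this exchange. Going by the values given here, the only step that bears on it is the one from compound 1, where a hydroxy was exchanged for chloromethyl and the number fell. Compound 3 carries a hydroxy again, so a modest rise toward the level of compound 1 is expected, a 1.9-fold higher number from compound 2 to compound 3 (0.28 log units; within the scatter). Compound 3 is therefore estimated at 400 nM, within 150 nM to 1100 nM.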

Compound 3, half-maximal inhibitory concentration: 14.1 nM
Estimate against measurement, compound 3: 28-fold (1.45 log units) above; the measured number lies below the stated range.
By their numbers in this assay, from the lowest: compound 3; then compound 2; then compound 1.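

In this assay the exchange of chloro for hydroxy gives a 15-fold lower number from compound 2 to compound 3 (1.17 log units; beyond the scatter) and makes compound 3 the lowest of the three, so a hydroxy on this saturated chain carbon carries no penalty. Hydroxymethyl in place of hydroxy on the aromatic carbon gives a 35-fold lower number from compound 1 to compound 3 (1.54 log units; beyond the scatter) and shows that a hydroxy on the chain carbon cannot be read like one on the aromatic carbon. Nothing available explains a change of this size. Still open, on these data alone, is whether the low number needs the free hydroxy, or whether methoxymethyl, aminomethyl or a longer hydroxyethyl chain in its place would give a similar number.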